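Cutting the chain back to methoxy

The source may report more compounds than this note shows. Statements on the series, on what has been measured and on what is new or still open speak of the compounds shown alone.

In a functional assay on T98G cells (Homo sapiens) for inhibition, read by colorimetric assay and MTT assay, with a stated time of 72 h (a lower number here means a stronger inhibitor, a higher number a weaker inhibitor), compound 1 (`CCCCOc1ncc(-c2ccccc2OC)n1C`) gives 96000 nM as its reading, and compound 2 (`CCCCCCOc1ncc(-c2ccccc2OC)n1C`) gives 58000 nM on the same core. Compound 3 (`C#CCCCCOc1ncc(-c2ccccc2OC)n1C`) reads 35000 nM here, which places it within the scatter of compound 2 but clear of compound 1. The change to compound 4 (`COc1ccccc1-c1cnc(OC)n1C`) is hydrogen in place of pent-4-yn-1-yl on a saturated chain carbon bound to an oxygen on an aromatic ring. For the measured compounds named here, three measured steps bear on it. Both a 1.7-fold lower number from compound 1 to compound 2 (0.22 log units; within the scatter) and a 1.7-fold lower number from compound 2 to compound 3 (0.22 log units; within the scatter) stay small, while a 2.7-fold lower number from compound 1 to compound 3 (0.44 log units; beyond the scatter) is the only one to leave the scatter. Going by the values given here, all three extend a chain at its far end, and no measured compound has a chain as short as methyl, so this is an extrapolation. Read in reverse, the step to compound 3 points towards a higher number, and a modest loss is expected. The estimated step is a 3.4-fold higher number from compound 3 to compound 4 (0.54 log units; beyond the scatter) in this assay (an expectation only). In this assay the estimated value for compound 4 is 120000 nM (expected range 50000 nM to 280000 nM).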

Compound 4, half-maximal inhibitory concentration: > 100000 nM
Compound 4: no number, only a limit; the forecaster's own chance of this, stated with the estimate: 25%; the middle value is on the limit's open side.
By their numbers in this assay, from the lowest: compounds 3, 2 and 1 (each within the scatter of the next, the first and the last beyond it). At a limit, above all of these: compound 4.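

In this assay, compound 4 gives no number, only a limit of the assay: the limit of > 100000 nM in this assay, at which 1 of the 4 values shown sits.

Even so, cutting the (hex-5-yn-1-yl)oxy group back to methoxy is a loss that clears the scatter, with an at least 2.8-fold higher number from compound 3 to compound 4 (0.45 log units; beyond the scatter). The steps from the two saturated chains, an at least 1.7-fold higher number from compound 2 to compound 4 (0.23 log units; that floor lies within the scatter) and an at least 1.0-fold higher number from compound 1 to compound 4 (0.01 log units; that floor lies within the scatter), have floors that lie within the scatter, so the limit cannot show how far methoxy falls short of those chains.

The compounds shown leave open how far beyond the limit compound 4 really lies and whether an ethoxy group would already give a measurable reading. They also leave open whether a longer chain, or an amine or a carboxylic acid at the chain end, would match the terminal alkyne of compound 3.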